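From 2-Methylphenyl to 4-Methoxyphenyl: Expected Cytotoxicity

The source may report more compounds than this note shows. Statements on the series, on what has been measured and on what is new or still open speak of the compounds shown alone.

Three compounds were examined in an ADME assay on Vero cells (Chlorocebus sabaeus) for cytotoxicity, read by resazurin assay, with a stated time of 3 days; a lower number here means that less compound is tolerated, a higher number that more compound is tolerated. Compound 1 `Cc1ccccc1Nc1nc(N)nc(CSc2nnc(-c3ccncc3)n2-c2ccccc2)n1` gives 1650 ug/mL, and compound 3 `COc1ccc(Nc2nc(N)nc(CSc3nnc(-c4ccccc4)n3/N=C/c3ccccc3)n2)cc1` gives 1500 ug/mL. Compound 2 `Cc1ccc(Nc2nc(N)nc(CSc3nc4cc(C)ccc4[nH]3)n2)cc1` belongs to the same series, but in this assay compound 2 gives "not determined" (no result reported). Of the two numbers in hand, compound 1 stands at the top, yet its gap to compound 3 lies within the usual scatter of repeated measurements, so the two cannot be separated on this evidence.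

Compound 4 `COc1ccc(Nc2nc(N)nc(CSc3nnc(-c4ccncc4)n3-c3ccccc3)n2)cc1` has not yet been measured in this assay. It differs from compound 1 in one place: 4-methoxyphenyl in place of 2-methylphenyl on a nitrogen on an aromatic ring. Among the compounds with values here, compound 3 carries the same 4-methoxyphenyl on a nitrogen on an aromatic ring, but its structure also differs elsewhere from compound 4, so no single-change step between measured compounds is available.

Nothing in the two numbers points to a change of any size, and the expected step is a 1.1-fold lower number from compound 1 to compound 4 (0.03 log units; within the scatter), which amounts to none beyond the scatter. The reasoning leans on compound 3, which with the same 4-methoxyphenyl gives 1500 ug/mL. Compound 4 is accordingly expected to give about 1550 ug/mL, with a range from 900 ug/mL to 2500 ug/mL.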

Compound 4, half-maximal cytotoxic concentration: 1500 ug/mL
The estimate for compound 4 lay 1.0-fold (0.01 log units) above the measured number; the measured number falls inside the stated range.
By their numbers in this assay, from the lowest: compounds 3, 4 and 1 (each within the scatter of the next).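

Within the data shown here, this is the first step that changes one place alone. In this assay, putting 4-methoxyphenyl in place of 2-methylphenyl on a nitrogen on an aromatic ring gives a 1.1-fold lower number from compound 1 to compound 4 (0.04 log units; within the scatter), so the two groups cannot be told apart at this place, even though the entering group brings one more heavy atom, an oxygen, and a hydrogen-bond acceptor that the leaving group lacks. Compound 3 could not show this, as it differs from compound 4 elsewhere as well, whereas this pair holds the rest of the structure fixed, and no measurement at hand offers an explanation for the outcome.

The result covers only these two substituted phenyl groups on the core of compound 1, and it does not show whether the same holds on the other structures in the series. Going by these compounds, whether a markedly different group at this place, such as a carboxylic acid, an amine or a longer alkyl chain, would also leave the number within the scatter remains open.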